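A few compounds are considered here, and "the series" means these few. Any claim that something is new, unique, unknown or untested is made for them only; others in the source may bear on it.

Working notes on the series.

Compound 1 `Nc1nc(Cl)c2ncn(Cc3ccccc3CCl)c2n1` is the reference point. In a functional assay on SW-620 cells (Homo sapiens) for cytotoxicity, read by sulforhodamine B assay, with a stated time of 48 h (a higher number here means that more compound is tolerated, a lower number that less compound is tolerated), compound 1 gives only a limit, > 100000 nM, and no number. Of the three values shown, compound 1 is the one that sits at the limit of > 100000 nM in this assay, at which 1 of the 3 values shown sits, so its standing is known only as a limit. Two further members of the series carry chloro at both positions on the core. Compound 2 `ClCc1cccc(Cn2cnc3nc(Cl)nc(Cl)c32)c1` gives 4070 nM in this assay. Compound 3 `ClCc1ccc(Cn2cnc3c(Cl)nc(Cl)nc32)cc1` gives 56200 nM in this assay. Among the compounds with values here, no step between measured compounds that differ in a single place is available, so nothing is known directly about what one change does.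

The unmeasured compound 4 `ClCc1ccccc1Cn1cnc2c(Cl)nc(Cl)nc21` is reached from compound 1 by a single change: chloro in place of amino on an aromatic carbon.

With compound 1 at a limit, the step to compound 4 cannot be read from the data, only expected. Given that compound 1 rests at the limit of > 100000 nM in this assay, at which 1 of the 3 values shown sits, while compound 2 gives 4070 nM and compound 3 gives 56200 nM with chloro at the same place, the expected direction for compound 4 is toward less compound tolerated. The expected step is an at least 5.0-fold lower number from compound 1 to compound 4 (0.69 log units; beyond the scatter), beyond the usual scatter. Compound 4 is estimated at 20000 nM in this assay, with a range from 4000 nM to 100000 nM.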

Compound 4, concentration lethal to 50% of the cells: 810 nM
Estimate against measurement, compound 4: 25-fold (1.39 log units) above; measured number outside the range, below it.
By their numbers in this assay, from the lowest: compound 4; then compound 2; then compound 3. At a limit, above all of these: compound 1.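

In this assay, within the data shown here, the replacement of amino by chloro gives the first direct reading at this position (an at least 120-fold lower number from compound 1 to compound 4 (2.09 log units; beyond the scatter)), and with nothing else in the structure changed, this step belongs to the aromatic carbon between two ring nitrogen atoms alone. Compound 2 and compound 3 already carried chloro there, but each differs from compound 1 in more than one place, so neither could isolate this change. The step remains a bound and its full size cannot be read, because compound 1 has only a limit and no number: the limit of > 100000 nM in this assay, at which 1 of the 4 values shown sits.

Open, going by these compounds, is whether the step comes from losing amino or from gaining chloro, which a hydrogen, a methoxy group or a methylamino group at this place would help to separate. Also open, on these data alone, is whether amino in place of chloro on compound 2 or compound 3 would give a step of similar size, and whether a methyl or hydroxymethyl group in place of the chloromethyl group would keep the number of compound 4.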